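Thiophene-to-pyridine swap on the pyrazole core

The source may hold more compounds than are shown below. What is called first, only, known or untested is meant among the compounds shown, and "the series" means these compounds.

Compound 1 `COc1cc(C(=O)/C=C/c2cn(-c3ccccc3)nc2-c2ccsc2)cc(OC)c1OC` gives 4900 nM in a functional assay on MCF7 cells (Homo sapiens) for inhibition, read by sulforhodamine B assay, with a stated time of 72 h (a lower number here means a stronger inhibitor, a higher number a weaker inhibitor), second highest of three numbers; compound 2 `COc1ccc(C(=O)/C=C/c2cn(-c3ccccc3)nc2-c2ccsc2)cc1OC` gives 2800 nM and compound 3 `COc1ccc(C(=O)/C=C/c2cn(-c3ccccc3)nc2-c2ccsc2)c(OC)c1` gives 9000 nM. For the measured compounds named here, the two steps so far, a 1.8-fold lower number from compound 1 to compound 2 (0.24 log units; within the scatter) and a 3.2-fold higher number from compound 2 to compound 3 (0.51 log units; beyond the scatter), both alter the methoxyphenyl ketone side. Compound 4 `COc1cc(C(=O)/C=C/c2cn(-c3ccccc3)nc2-c2ccncc2)cc(OC)c1OC` instead changes the aryl on the shared core: pyridin-4-yl in place of thiophen-3-yl on an aromatic carbon. Going by the values given here, no measured step touches this position, so nothing here bears on it directly, and no direction can be argued from the series. The expectation is therefore a step of no more than the scatter, no change at the digits printed from compound 1 to compound 4 (within the scatter). Compound 4 is thus estimated at 4900 nM, with a broad range from 1500 nM to 16000 nM.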

Compound 4, half-maximal inhibitory concentration: 3500 nM
For compound 4 the middle estimate is 1.4-fold (0.15 log units) above the measured one; the range from low to high includes it.
By their numbers in this assay, from the lowest: compounds 2, 4, 1 and 3 (each within the scatter of the next, the first and the last beyond it).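

Pyridin-4-yl in place of thiophen-3-yl gives a 1.4-fold lower number from compound 1 to compound 4 (0.15 log units; within the scatter) in this assay, the first reading at this position on the shared core. With the ketone side of compound 1 held fixed, the six-membered ring is accepted here as well as the five-membered one, at this level of activity. Nothing measured bears on why the two aryl groups read alike.

Left open is whether this swap reads the same on the ketone sides of compound 2 and compound 3, and how a piperidine or a carboxylic acid would read at this position.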